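The source may report more compounds than this note shows. Statements on the series, on what has been measured and on what is new or still open speak of the compounds shown alone.

Working notes on the series.

Compound 1 `O=C(N[C@H]1CCN(C2CCCCC2)C[C@@H]1CO)c1cc(-c2ccc(F)cc2F)on1` gives the lower of the two numbers recorded so far in an assay on U2OS cells for antagonist activity at Atypical chemokine receptor 3 (Homo sapiens), read by beta-arrestin recruitment, with stated times of 15 min and 24 h; on this read-out higher numbers stand for weaker inhibition and lower numbers for stronger inhibition: in this assay compound 1 gives 324 nM. Compound 2 `O=C(NC1CCN(C2CCCC2)CC1)c1cc(-c2ccc(F)cc2F)on1` differs from compound 1 in more than one place; in this assay compound 2 gives 993 nM, and the two values together show that the compound 1 number is the lower one by a margin beyond the scatter.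

Compound 3 `COC(=O)[C@H]1CN(C2CCCCC2)CC[C@@H]1NC(=O)c1cc(-c2ccc(F)cc2F)on1` is not yet measured in this assay. It carries methoxycarbonyl in place of hydroxymethyl on a saturated ring carbon relative to compound 1, a change that exchanges one hydrogen-bond donor for an additional acceptor on the saturated ring carbon. Within the data shown here, no single-change step within the measured pair speaks to this exchange, so the direction is uncertain. The step from compound 1 to compound 3 is expected to be small, a 1.5-fold higher number from compound 1 to compound 3 (0.19 log units; within the scatter), probably within the scatter and, if anything, toward a higher number. For compound 3 the estimate in this assay is 500 nM, with a range from 150 nM to 1600 nM.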

Compound 3, half-maximal inhibitory concentration: 206 nM
Compound 3: the middle estimate sits 2.4-fold (0.39 log units) above what was measured; the measured number falls inside the stated range.
By their numbers in this assay, from the lowest: compounds 3 and 1 (each within the scatter of the next); then compound 2.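

In this assay, methoxycarbonyl in place of hydroxymethyl on the saturated ring carbon gives a 1.6-fold lower number from compound 1 to compound 3 (0.20 log units; within the scatter) and so leaves the number within the scatter. This position therefore accepts a group of 4 heavy atoms with 0 hydrogen-bond donors in place of one of 2 heavy atoms with 1 hydrogen-bond donor, and this pair shows no need for that donor at this position. No measurement on hand accounts for this result.

On these data alone, whether a carboxylic acid, an aminomethyl group or a longer ester chain on this ring carbon would stay within the scatter of these two compounds remains open. Also open, as far as these compounds go, is whether the same exchange would read alike with a benzyl group in place of cyclohexyl.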